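This account rests on a few compounds, and the source may have more. Where it says the series, first, only, none or still open, it means among the compounds named here.

Working notes on the series. Compound 1 `CN(C)CCNc1nc(-c2ccc(NC(=O)Nc3ccccc3Cl)cc2)nc2ccsc12` is the reference; in a functional assay on MKN-45 cells (Homo sapiens) for cytotoxicity, read by MTT assay, with a stated time of 72 h (a higher number here means a weaker inhibitor, a lower number a stronger inhibitor), compound 1 gives 850 nM. Compound 3 `CN(C)CCNc1nc(-c2ccc(NC(=O)Nc3ccc(Cl)cc3Cl)cc2)nc2ccsc12` carries the change (chloro in place of hydrogen on an aromatic carbon), and in this assay compound 3 gives 2360 nM, so that the step is a 2.8-fold higher number from compound 1 to compound 3 (0.44 log units; beyond the scatter). Compound 2 `CN(C)CCNc1nc(-c2ccc(NC(=O)Nc3ccccc3Cl)cc2)nc2c(Cl)c(Cl)sc12` has a different core; how the two cores differ is not broken down here. In this assay compound 2 gives 1170 nM, which lies within the scatter of compound 1 and of compound 3, so no order among the three is claimed.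

Compound 4 `CN(C)CCNc1nc(-c2ccc(NC(=O)Nc3ccc(Cl)cc3Cl)cc2)nc2c(Cl)c(Cl)sc12` is not yet measured. It differs from compound 2 by chloro in place of hydrogen on an aromatic carbon, the same change as that from compound 1 to compound 3, described at a place given in the same words. If that change carries over to the core of compound 2, the expected step is a 2.8-fold higher number from compound 2 to compound 4 (0.45 log units; beyond the scatter), resting on a 2.8-fold higher number from compound 1 to compound 3 (0.44 log units; beyond the scatter). With a single earlier example of the change, the carry-over is uncertain and the range is kept wide. Compound 4 is estimated in this assay at 3300 nM, with an expected range from 1500 nM to 7000 nM.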

Compound 4, half-maximal inhibitory concentration: 3460 nM
Estimate against measurement, compound 4: 1.0-fold (0.02 log units) below; the measured number falls inside the stated range.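

In this assay, going from 2-chlorophenyl to 2,4-dichlorophenyl gives a 3.0-fold higher number from compound 2 to compound 4 (0.47 log units; beyond the scatter), so adding the chloro weakens the compound on the core of compound 2 as well. The step keeps its size from one core to the other: the same change on two cores in this assay, a 2.8-fold higher number (0.44 log units; beyond the scatter) from compound 1 to compound 3 and a 3.0-fold higher number (0.47 log units; beyond the scatter) from compound 2 to compound 4, 1.1-fold (0.03 log units) apart, within the scatter of two such steps. This shows that the change carries over between these two cores in this one assay, but it rests on a single pair per core and does not show that the change would carry over to any other core or any other assay, nor does it explain why the number rises.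

The compounds shown leave open whether a fluoro, methoxy or trifluoromethyl group on the same aromatic carbon would give a step of similar size to that of chloro. They also leave open whether the step would persist if the dimethylamino group were replaced by a morpholine or a carboxylic acid, or if a longer chain carried it.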